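The source may report more compounds than this note shows. Statements on the series, on what has been measured and on what is new or still open speak of the compounds shown alone.

Compound 1 `CCCn1c(=O)[nH]c2nc(-c3ccc(S(=O)(=O)N4CCN(c5ccc(F)cc5)CC4)cc3)[nH]c2c1=O`: 0.644 nM in an assay on CHO cells for displacement of a labelled ligand from adenosine receptor A2b (Homo sapiens), read by scintillation counting, with a stated time of 75 min, in the presence of a further agent that is not named here; on this read-out higher numbers stand for weaker inhibition and lower numbers for stronger inhibition.
Compound 2 `CCCn1c(=O)[nH]c2nc(-c3ccc(S(=O)(=O)N4CCN(C)CC4)cc3)[nH]c2c1=O`: 48.2 nM.
Compound 3 `CCCn1c(=O)[nH]c2nc(-c3ccc(S(=O)(=O)N4CCN(c5cccc(Br)c5)CC4)cc3)[nH]c2c1=O`: 0.234 nM.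

Among the three measured compounds, compound 3 gives the lowest number in this assay. Compound 1 comes nearest, and the step of a 2.8-fold lower number from compound 1 to compound 3 (0.44 log units; beyond the scatter) lies beyond the scatter, as does the far larger step a 210-fold lower number from compound 2 to compound 3 (2.31 log units; beyond the scatter). Compound 4 `CCCn1c(=O)[nH]c2nc(-c3ccc(S(=O)(=O)N4CCN(c5cccc(F)c5)CC4)cc3)[nH]c2c1=O` differs from compound 3 in one place: fluoro in place of bromo on an aromatic carbon. Within the data shown here, no measured step exchanges one halogen for another on that ring. The steps of a 75-fold higher number from compound 1 to compound 2 (1.87 log units; beyond the scatter) and a 210-fold lower number from compound 2 to compound 3 (2.31 log units; beyond the scatter) set methyl against an aryl group, and a 2.8-fold lower number from compound 1 to compound 3 (0.44 log units; beyond the scatter) swaps 4-fluorophenyl for 3-bromophenyl, changing two things at once. The step of a 1.7-fold higher number from compound 3 to compound 4 (0.23 log units; within the scatter) is therefore expected to be small, if any. Compound 4 is expected to give about 0.4 nM, most likely between 0.15 nM and 1.2 nM.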

Compound 4, inhibition constant: 0.632 nM
Beside the measured number, compound 4's estimate is 1.6-fold (0.20 log units) below it, within the range that was stated.
By their numbers in this assay, from the lowest: compound 3; then compounds 4 and 1 (each within the scatter of the next); then compound 2.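

In this assay, among these compounds, exchanging bromo for fluoro on this aromatic carbon has a real effect (a 2.7-fold higher number from compound 3 to compound 4 (0.43 log units; beyond the scatter)), the first direct swap of one halogen for another on this ring. The 3-fluorophenyl and 4-fluorophenyl groups cannot be told apart (a 1.0-fold lower number from compound 1 to compound 4 (0.01 log units; within the scatter)). Even so, 3-fluorophenyl still stands far ahead of methyl on the ring nitrogen (a 76-fold lower number from compound 2 to compound 4 (1.88 log units; beyond the scatter)).

On these data alone, whether chloro or methoxy on the same carbon would match bromo or fluoro stays open. Nothing shown here explains the gap between bromo and fluoro.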